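Working notes: from compound 2 to compound 4

The compounds below may be only part of what the source reports. "The series", "measured", "known", "first", "only" and "open" are said of these compounds alone.

In a physicochemical assay for acid dissociation, compound 2 `COc1ccnc(C[S+]([O-])c2nc3cc(OCC(F)(F)F)ccc3[nH]2)c1OC` gives 8.52. Compound 3 `COc1ccnc(C[S+]([O-])c2nc3cc(OCC(F)(F)F)ccc3[nH]2)c1C` gives 8.51, and compound 1 `COc1c(C)cnc(C[S+]([O-])c2nc3cc(OC(F)F)ccc3[nH]2)c1C` gives 8.23. All of these values lie within the scatter of compound 2, so compound 2 stands level with both others.

The next structure is compound 4 `COc1ccnc(C[S+]([O-])c2nc3cc(OC(F)(F)C(F)F)ccc3[nH]2)c1OC`, with 1,1,2,2-tetrafluoroethyl in place of 2,2,2-trifluoroethyl on an oxygen on an aromatic ring.

Among the measured compounds shown here, the only measured single change is methyl in place of methoxy on an aromatic carbon, a number 0.01 log units lower from compound 2 to compound 3 (within the scatter). For the measured compounds named here, it leaves the group on that oxygen untouched, so it bears on the new change only indirectly, and no measured step tests the change itself. The narrow spread of the three values, from compound 1 at 8.23 to compound 2 at 8.52, is the main guide, and no step beyond the scatter is expected in this assay.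

The expected change is a number 0.17 log units lower from compound 2 to compound 4 (within the scatter).

For compound 4 the estimated value is 8.35, with an expected range of 8.05 to 8.6.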

Compound 4, acid dissociation constant: 8.08
For compound 4 the middle estimate is 0.27 log units above the measured one, within the range that was stated.
By their numbers in this assay, from the lowest: compounds 4, 1, 3 and 2 (each within the scatter of the next, the first and the last beyond it).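

In this assay the group on an oxygen on an aromatic ring is, among the changes shown, the one place where a single change goes beyond the scatter: 1,1,2,2-tetrafluoroethyl in place of 2,2,2-trifluoroethyl gives a number 0.44 log units lower from compound 2 to compound 4 (beyond the scatter). The other single change, methyl in place of methoxy on an aromatic carbon, gives a number 0.01 log units lower from compound 2 to compound 3 (within the scatter), so the read-out in this series is not flat to every single change. Nothing measured here gives a reason for the size or direction of this step.

Two fluorinated groups on this oxygen cannot show whether the step follows the fluorine count or the particular arrangement of the chain. An unfluorinated ethyl group, a longer chain such as propyl or an amine in this place would each test how far the trend extends.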